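Reshuffling the bicyclic arm on the shared core

The source may report more compounds than this note shows. Statements on the series, on what has been measured and on what is new or still open speak of the compounds shown alone.

Of the compounds shown here, three with a shared core have been measured in a physicochemical assay for lipophilicity, at pH 7.4; a higher number here means a more lipophilic compound, a lower number a more polar compound. Compound 1 `CNC(=O)c1cc(C(=O)NC2CC2)cn(Cc2cccc(OC)c2)c1=O` gives 3. Compound 2 `CNC(=O)c1cc(C(=O)NC2CC2)cn(Cc2ccc3nc[nH]c3c2)c1=O` gives 1.2. Compound 3 `CNC(=O)c1cc(C(=O)NC2CC2)cn(Cc2nccc3[nH]ccc23)c1=O` gives 1.7, which places it second highest of the three: its nearest neighbour is compound 2, and its furthest is compound 1. The measured steps are a number 1.80 log units lower from compound 1 to compound 2 (beyond the scatter), a number 1.30 log units lower from compound 1 to compound 3 (beyond the scatter) and a number 0.50 log units higher from compound 2 to compound 3 (beyond the scatter).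

Compound 4 `CNC(=O)c1cc(C(=O)NC2CC2)cn(Cc2cccc3cn[nH]c23)c1=O` has the same atoms as compound 3, joined differently: a group of 9 heavy atoms (7 carbon, 2 nitrogen; one five-membered aromatic ring with 2 hetero atoms, one six-membered aromatic ring of carbon only) in place of a group of 9 heavy atoms (7 carbon, 2 nitrogen; one five-membered aromatic ring with 1 hetero atom, one six-membered aromatic ring with 1 hetero atom), on a saturated chain carbon bound to an aromatic nitrogen. Among the compounds with values here, the step that bears most on this change is the one between compound 2 and compound 3, which ran in the opposite sense, from a five-membered aromatic ring with 2 hetero atoms and a six-membered aromatic ring of carbon only to the arrangement found in compound 3. Compound 4 returns to that earlier kind of arrangement, though with the 1H-indazol-7-yl group rather than the group of compound 2, so only a small downward movement is expected, likely within the scatter. The step from compound 3 to compound 4 in this assay is therefore expected to be a number 0.20 log units lower from compound 3 to compound 4 (within the scatter). For compound 4 the estimate is 1.5, with a range from 1 to 2.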

Compound 4, distribution coefficient: 2.2
For compound 4 the middle estimate is 0.70 log units below the measured one; the whole stated range lies below it.
By their numbers in this assay, from the lowest: compound 2; then compound 3; then compound 4; then compound 1.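

Within the data shown here, at the saturated chain carbon bound to an aromatic nitrogen, this assay responds to how the atoms of the bicyclic group are joined, and not only to which atoms they are: exchanging one arrangement of the same atoms for 1H-indazol-7-yl gives a number 0.50 log units higher from compound 3 to compound 4 (beyond the scatter), a step opposite in sense to the small fall that the earlier compounds had suggested. The kinds of ring do not settle the number either, as 1H-benzimidazol-6-yl and 1H-indazol-7-yl each have one five-membered aromatic ring with 2 hetero atoms and one six-membered aromatic ring of carbon only, and yet the exchange gives a number 1.00 log units higher from compound 2 to compound 4 (beyond the scatter) at this place. Even so, 1H-indazol-7-yl stays short of 3-methoxyphenyl, with a number 0.80 log units lower from compound 1 to compound 4 (beyond the scatter), and all three bicyclic groups shown lie on the lower side of that single-ring group.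

Nothing measured here accounts for these differences. The compounds shown also leave open where a 1H-indazol-5-yl group or a plain naphthyl group would fall at this place, and so whether the number follows the point of attachment, the placing of the ring nitrogens, or both.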